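A few compounds are considered here, and "the series" means these few. Any claim that something is new, unique, unknown or untested is made for them only; others in the source may bear on it.

Compound 1 `Cc1cnc(Nc2ccc(S(C)(=O)=O)cc2)nc1Nc1nc2ccccc2s1` and compound 2 `Cc1cnc(Nc2ccc(F)cc2)nc1Nc1nc2ccccc2s1` share one core and differ in a single group on an aromatic carbon. In a functional assay on PC-3 cells (Homo sapiens) for antiproliferative activity, read by MTT assay, with a stated time of 48 h (a higher number here means a weaker inhibitor, a lower number a stronger inhibitor), compound 1 gives no number, only a limit, > 50000 nM. In this assay compound 2 likewise gives only a limit, > 50000 nM. The change of fluoro in place of methylsulfonyl on an aromatic carbon is therefore a step whose size cannot be read, a step that the two limits leave unreadable from compound 1 to compound 2, because both values sit at the limit of > 50000 nM in this assay, at which 2 of the 2 values shown sit.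

Compound 3 `Cc1cnc(Nc2cccc(F)c2)nc1Nc1nc2ccccc2s1` keeps the same atoms as compound 2 but joins them differently: 3-fluorophenyl in place of 4-fluorophenyl on a nitrogen on an aromatic ring. For the measured compounds named here, no measured pair in this set moves the fluorine around that ring, so the only step that bears on this change is the unreadable one from compound 1 to compound 2, which cannot point in any direction. With compound 2 standing at a limit in this assay, the expectation for compound 3 is a step that the limit leaves unreadable from compound 2 to compound 3, that is, nothing beyond the scatter, and compound 3 is expected to give roughly 80000 nM, within a range of 20000 nM to 300000 nM, most likely again as a limit rather than a number.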

Compound 3, half-maximal inhibitory concentration: > 50000 nM
Compound 3 gave a limit, no number; the forecaster's own chance of this, stated with the estimate: 80%; the middle value lies beyond the limit too.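

No step can be read from compound 2 to compound 3, because each gives only a limit and no number: the limit of > 50000 nM in this assay, at which 3 of the 3 values shown sit.

The compounds shown leave open whether 3-fluorophenyl and 4-fluorophenyl differ in activity at all, and whether any change to the shared core would give a readable number.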